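Removing a Hydroxy From a Cytotoxic Natural-Product Scaffold

The source may hold more compounds than are shown below. What is called first, only, known or untested is meant among the compounds shown, and "the series" means these compounds.

Of the compounds shown here, two sharing one large polycyclic core have been tested in a functional assay on HeLa C3 cells (Homo sapiens) for cytotoxicity, read by MTT assay, with a stated time of 72 h; on this read-out lower numbers stand for stronger inhibition and higher numbers for weaker inhibition. Compound 1, `C=C(C)C(O)C[C@H](C[C@@]12C[C@@H](CC=C(C)C)C(C)(C)[C@@](CC=C(C)C)(C(=O)C(C(=O)c3ccc(O)c(O)c3)=C1O)C2=O)C(=C)C`, carries a hydroxy on one of its side chains; compound 2, `C=C(C)[C@H](CC=C(C)C)C[C@@]12C[C@@H](CC(O)C(C)(C)O)C(C)(C)[C@@](CC=C(C)C)(C(=O)C(C(=O)c3ccc(O)c(O)c3)=C1O)C2=O`, carries a diol on a different side chain. In this assay compound 1 gives 14300 nM, and compound 2 gives 14900 nM. The two numbers sit so close together that they cannot be told apart within the usual scatter of repeated measurements, so compound 1 stands level with compound 2 rather than apart from it.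

Compound 3, `C=C(C)CC[C@H](C[C@@]12C[C@@H](CC=C(C)C)C(C)(C)[C@@](CC=C(C)C)(C(=O)C(C(=O)c3ccc(O)c(O)c3)=C1O)C2=O)C(=C)C`, has not yet been measured in this assay. It differs from compound 1 in one place: hydrogen in place of hydroxy on a saturated chain carbon bound to a double-bonded chain carbon and a saturated chain carbon. Among the compounds with values here, no measured pair shows the effect of exactly this change, so the expectation rests on the single point from compound 1. The step of a 1.2-fold lower number from compound 1 to compound 3 (0.08 log units; within the scatter) is expected to be small, in whichever direction it falls, and most likely within the scatter of repeated runs. Compound 3 is therefore estimated to give about 12000 nM in this assay, with a plausible range from 5000 nM to 30000 nM.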

Compound 3, half-maximal inhibitory concentration: 12400 nM
The estimate for compound 3 lay 1.0-fold (0.01 log units) below the measured number, and the stated range covers the measured number.
By their numbers in this assay, from the lowest: compounds 3, 1 and 2 (each within the scatter of the next).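

Taking the hydroxy off this saturated chain carbon, bound to a double-bonded chain carbon and a saturated chain carbon, gives a 1.2-fold lower number from compound 1 to compound 3 (0.06 log units; within the scatter) in this assay. Within the data shown here, the two earlier compounds differ in more than one place, so this is the first step that isolates a single group: a 2-hydroxy-3-methylbut-3-en-1-yl chain and a 3-methylbut-3-en-1-yl chain cannot be told apart in this read-out, and the hydroxy at this position can go with no change that the assay can detect. Nothing available explains why this change leaves so little mark on the number.

The compounds shown leave open whether this carbon tolerates any larger change, such as an amine, a carboxylic acid or a longer chain in place of the hydroxy, since hydrogen and hydroxy are the only two groups seen here. Among these compounds, they also leave open what the diol on the other side chain of compound 2 contributes, as no step that differs in one place reaches that group.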